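Removing the sulfamoyl group from compound 2

The compounds below may be only part of what the source reports. "The series", "measured", "known", "first", "only" and "open" are said of these compounds alone.

Measured so far:
Compound 1 `CSc1ncnc2c1ncn2C1CC(COS(N)(=O)=O)C(O)C1O` gives 50 ug/mL
Compound 2 `Nc1ncnc2c1nnn2C1CC(COS(N)(=O)=O)C(O)C1O` gives 0.0625 ug/mL

In a functional assay on P388 cells (Mus musculus) for cytotoxicity (on this read-out higher numbers stand for weaker inhibition and lower numbers for stronger inhibition), compound 2 at 0.0625 ug/mL holds the lower of the two numbers, and its gap to compound 1 lies beyond the usual scatter. Compound 3 `Nc1ncnc2c1nnn2C1CC(CO)C(O)C1O` has not yet been measured. It differs from compound 2 by a single change hydrogen in place of sulfamoyl on an oxygen on a saturated carbon with hydrogen in place of sulfamoyl on an oxygen on a saturated carbon, so that sulfamoyloxy becomes hydroxy. Among the compounds with values here, no measured pair isolates this change, so its size in this assay remains a matter of judgement. A step toward a higher number, meaning weaker inhibition, is expected to lie well beyond the scatter, because compound 2 at 0.0625 ug/mL has much room to rise toward compound 1 at 50 ug/mL. The expected change is a step of a 160-fold higher number from compound 2 to compound 3 (2.20 log units; beyond the scatter) with wide uncertainty. For compound 3 the estimated value is 10 ug/mL with an expected range from 1.5 ug/mL to 60 ug/mL as its likely span.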

Compound 3, half-maximal inhibitory concentration: 0.5 ug/mL
Compound 3: middle estimate off by 20-fold (1.30 log units), on the high side; measured number below the stated range.
By their numbers in this assay, from the lowest: compound 2; then compound 3; then compound 1.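

In this assay, within the data shown here, replacing sulfamoyl with hydrogen, so that sulfamoyloxy becomes hydroxy, gives an 8.0-fold higher number from compound 2 to compound 3 (0.90 log units; beyond the scatter) and isolates this change for the first time. The pair shows that the sulfamoyl group on this oxygen on a saturated carbon contributes to inhibition in this read-out by more than the scatter of repeated measurements. Even so, compound 3 gives 0.5 ug/mL without it, and this remains well below the printed value of compound 1, although those two compounds differ in more than one place and cannot be read as a single change. No available evidence accounts for the size of this step.

Going by these compounds, whether the same replacement would have a step of similar size on the core of compound 1 remains open, since this single pair rests on the core of compound 2 and compound 3. The compounds shown also leave open how an amine or a carboxylic acid in place of the hydroxy would read in this assay, and so whether sulfamoyloxy is unusual at this place or only one of several groups that strengthen inhibition.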